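From Compound 3 to Compound 4: A Chloro Step

The source may report more compounds than this note shows. Statements on the series, on what has been measured and on what is new or still open speak of the compounds shown alone.

- compound 1 `C#CCCCCOc1ncc(-c2ccccc2OC)n1C`: 10000 nM
- compound 2 `C=CCCOc1ncc(-c2ccccc2OC)n1C`: 27000 nM
- compound 3 `C=CCCCCOc1ncc(-c2ccccc2OC)n1C`: 5000 nM

These values come from a functional assay on MCF7 cells (Homo sapiens) for inhibition, read by colorimetric assay and MTT assay, with a stated time of 72 h; on this read-out higher numbers stand for weaker inhibition and lower numbers for stronger inhibition. The position of compound 3 is set by two steps: the data show a 2.0-fold lower number from compound 1 to compound 3 (0.30 log units; within the scatter), and a 5.4-fold lower number from compound 2 to compound 3 (0.73 log units; beyond the scatter). Compound 4 `C=CCCCCOc1ncc(-c2cc(Cl)ccc2OC)n1C` keeps the chain of compound 3 and has chloro in place of hydrogen on an aromatic carbon.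

Going by the values given here, no measured step bears directly on this change, since all three alter only the chain. They offer only a rough guide to size, with a 2.7-fold higher number from compound 1 to compound 2 (0.43 log units; beyond the scatter) and, as the widest, a 5.4-fold lower number from compound 2 to compound 3 (0.73 log units; beyond the scatter). The data do not fix a direction for the new step, so a modest move toward a lower number is only a tentative expectation. The expected change is a 1.4-fold lower number from compound 3 to compound 4 (0.15 log units; within the scatter). For compound 4, the estimated value is 3500 nM, with an expected range of 1000 nM to 12000 nM.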

Compound 4, half-maximal inhibitory concentration: 25000 nM
For compound 4 the middle estimate is 7.1-fold (0.85 log units) below the measured one, and the stated range ends below it.
By their numbers in this assay, from the lowest: compounds 3 and 1 (each within the scatter of the next); then compounds 4 and 2 (each within the scatter of the next).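

In this assay, chloro on an aromatic carbon para to a methoxy group gives a 5.0-fold higher number from compound 3 to compound 4 (0.70 log units; beyond the scatter), a step beyond the scatter and toward weaker inhibition. Going by these compounds alone, all the earlier steps changed only the chain, so this is the first sign that the read-out also responds to a change on this aromatic ring, and that a single chlorine atom here can shift it by a clear margin. Nothing in the data accounts for this shift.

On these data alone, whether fluoro, methyl or a nitrile at this carbon would move the number in the same direction as chloro remains open. As far as these compounds go, it is also open whether chloro would give a similar step at other carbons of this ring, or when paired with the chains of compound 1 and compound 2.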